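Thyrotropin receptor agonists: notes on the step to compound 4

The source may hold more compounds than are shown below. What is called first, only, known or untested is meant among the compounds shown, and "the series" means these compounds.

Measured compounds in a functional assay on HEK-EM293 cells for agonist activity at Thyrotropin receptor (Homo sapiens), read by ELISA and cAMP accumulation, with a stated time of 1 h; on this read-out higher numbers stand for larger maximal responses and lower numbers for smaller maximal responses:
compound 1, `COc1ccc(C2Nc3cccc(OC)c3C(=O)N2Cc2ccccc2)cc1COc1ccc(NC(C)=O)cc1`, gives 49.1%
compound 2, `COc1ccc(C2Nc3ccccc3C(=O)N2Cc2ccccc2)cc1COc1ccccc1`, gives 25.6%
compound 3, `COc1ccc(C2Nc3ccccc3C(=O)N2Cc2ccccc2)cc1COc1cccc(NC(C)=O)c1`, gives 24.8%

Compound 3 sits at the low end of the three numbers in this assay. Compound 2 lies beside it within the scatter, so no order between the two can be read. Within the data shown here, compound 1 stands clearly higher, but compound 1 and compound 3 differ in two places, so only their two values can be compared and no single step is drawn from them.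

The next compound, compound 4, `COc1ccc(C2Nc3ccccc3C(=O)N2Cc2ccccc2)cc1COc1cccc(F)c1`, differs from compound 3 by fluoro in place of acetamido on an aromatic carbon.

Among the measured compounds shown here, the one measured step that bears on this position is a number 0.8 percentage points lower from compound 2 to compound 3 (within the scatter): adding acetamido at this aromatic carbon left the response where it was. Going from acetamido to fluoro on the same carbon is expected to behave likewise, with no movement beyond the scatter in this assay, so the expected step is a number 0.2 percentage points higher from compound 3 to compound 4 (within the scatter).

Compound 4 is therefore estimated at 25%, with a range from 12% to 42%.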

Compound 4, largest response reached (Emax), in percent of the reference or control that the assay uses: 7.4%
The estimate for compound 4 lay 17.6 percentage points above the measured number, outside the stated range (below it).
By their numbers in this assay, from the lowest: compound 4; then compounds 3 and 2 (each within the scatter of the next); then compound 1.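

In this assay, the aromatic carbon meta to a large group proves sensitive to the group it carries, which the earlier step (a number 0.8 percentage points lower from compound 2 to compound 3 (within the scatter)) did not show: the exchange of acetamido for fluoro gives a clear drop (a number 17.4 percentage points lower from compound 3 to compound 4 (beyond the scatter)). The drop also appears against the unsubstituted ring (a number 18.2 percentage points lower from compound 2 to compound 4 (beyond the scatter)), so among the three groups seen on this carbon, hydrogen and acetamido cannot be told apart, while fluoro stands alone with a lower maximal response. No measurement shown here gives a reason for the lower response of the 3-fluorophenoxy compound.

Going by these compounds, whether this lower response belongs to fluoro alone stays open, and chloro, methyl, an amine or a carboxylic acid on the same carbon would show whether it extends to other groups. Among these compounds, it also remains open whether fluoro would lower the response on the core of compound 1, which differs from compound 4 in more than one place and so allows no single step to be read.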